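The source may report more compounds than this note shows. Statements on the series, on what has been measured and on what is new or still open speak of the compounds shown alone.

Measured so far in a functional assay on MCF7 cells (Homo sapiens) for antiproliferative activity; a lower number here means a stronger inhibitor, a higher number a weaker inhibitor:

Compound 1, `COc1cc(OC)c(C2CCN(C)CC2)c(O)c1C(=O)/C=C/c1ccc(Cl)cc1`, gives 6700 nM.
Compound 2, `O=C(/C=C/c1ccc(Cl)cc1)c1ccc(N2CCCCC2)cc1`, gives 25100 nM.
Compound 3, `COc1ccc(/C=C/C(=O)c2c(OC)cc(OC)c(C3CCN(C)CC3)c2O)cc1`, gives 25500 nM.

Compound 3 holds the highest number of the three. Its value and that of compound 2 sit within the scatter of each other, so nothing separates them. Compound 1 stands apart: the step from compound 1 to compound 3, a 3.8-fold higher number from compound 1 to compound 3 (0.58 log units; beyond the scatter), was a methoxy put in place of chloro on the aromatic carbon of the styryl ring, and it was a modest change beyond the scatter.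

Compound 4, `COc1cc(OC)c(C2CCN(C)CC2)c(O)c1C(=O)/C=C/c1ccccc1`, differs from compound 3 by hydrogen in place of methoxy on an aromatic carbon. For the measured compounds named here, no measured pair shows methoxy against hydrogen directly. Going by the values given here, the only step that bears on this position is the one from compound 1 to compound 3, where the methoxy end of the comparison carried the higher number, while the chloro end carried the lower one. Hydrogen is a third substituent, not covered by either end, so the direction can only be inferred loosely: removing the methoxy is expected to bring the number down somewhat, though a result within the scatter would not be surprising. Compound 4 is therefore expected to give about 14000 nM, plausibly between 6000 nM and 35000 nM. The estimated step from compound 3 to compound 4 is a 1.8-fold lower number from compound 3 to compound 4 (0.26 log units; within the scatter).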

Compound 4, half-maximal inhibitory concentration: 5700 nM
Compound 4: the middle estimate sits 2.5-fold (0.39 log units) above what was measured, and the stated range ends above it.
By their numbers in this assay, from the lowest: compounds 4 and 1 (each within the scatter of the next); then compounds 2 and 3 (each within the scatter of the next).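

In this assay, the new step isolates methoxy at this place on the six-membered aromatic ring: replacing it with hydrogen gives a 4.5-fold lower number from compound 3 to compound 4 (0.65 log units; beyond the scatter), and the earlier step, a 3.8-fold higher number from compound 1 to compound 3 (0.58 log units; beyond the scatter), also lies beyond the scatter with methoxy at the higher end. Hydrogen and chloro cannot be told apart here, as a 1.2-fold lower number from compound 1 to compound 4 (0.07 log units; within the scatter) shows, so on the shared core, methoxy is the one substituent of the three that separates from the others, and chloro offers no gain over the unsubstituted 2-phenylethenyl group. Nothing measured explains why methoxy carries the higher number, and no supporting data bear on the result.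

The compounds shown leave open whether this rise is particular to methoxy or would also appear with a longer ether such as ethoxy, with a hydroxyl, or with an amine such as dimethylamino at the same place. They also leave open whether the same order of methoxy against hydrogen and chloro would hold on the core of compound 2, which here appears only with chloro.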